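Working notes on a pyridyl swap in a small series

The source may report more compounds than this note shows. Statements on the series, on what has been measured and on what is new or still open speak of the compounds shown alone.

Of the compounds shown here, two carry numbers so far. Compound 1 `O=[N+]([O-])c1cc(-c2nc(-c3ccccc3)no2)cc(O)c1O` gives 20.6% in a functional assay on the whole organism (liver, strain NMRI) for inhibition, with Mus musculus as the target, with a stated time of 3 h, at a dose of 3 mg/kg by the oral route; on this read-out lower numbers stand for less inhibition and higher numbers for more inhibition at the one dose given (going by the name of the read-out). Compound 2 `O=[N+]([O-])c1cc(-c2cc(-c3cccnc3)no2)cc(O)c1O` gives 33.6% in this assay, the highest of the two numbers, and its gap to compound 1 lies beyond the scatter. Compound 3 `O=[N+]([O-])c1cc(-c2cc(-c3ccccn3)no2)cc(O)c1O` is not yet measured; it differs from compound 2 by pyridin-2-yl in place of pyridin-3-yl on an aromatic carbon. Among the compounds with values here, no measured pair shows this change, so the two values alone guide the expectation. Compound 3 is expected to stay close to compound 2, with a step of a number 3.6 percentage points lower from compound 2 to compound 3 (within the scatter) that need not exceed the scatter in either direction. In this assay compound 3 is estimated at 30%, between 15% and 45%.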

Compound 3, a percentage reported as inhibition, in the whole organism at one dose (the size of the read-out at that dose, not a potency): 27.5%
The estimate for compound 3 lay 2.5 percentage points above the measured number; the measured number falls inside the stated range.
By their numbers in this assay, from the lowest: compounds 1, 3 and 2 (each within the scatter of the next, the first and the last beyond it).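

With pyridin-2-yl in place of pyridin-3-yl on this aromatic carbon, next to the ring nitrogen, this assay gives a number 6.1 percentage points lower from compound 2 to compound 3 (within the scatter). Within the data shown here, this is the first one-place comparison, and on this read-out it does not separate the two pyridyl attachments at the one dose given. No measured property bears on this step, so the data offer no explanation for it.

The compounds shown leave open how pyridin-4-yl would read at this position. They also leave open whether an amine or a carboxylic acid on the same carbon would give a step beyond the scatter.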